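Working notes: from compound 2 to compound 4

This account rests on a few compounds, and the source may have more. Where it says the series, first, only, none or still open, it means among the compounds named here.

Measured so far:
- compound 1 `Nc1ncnc2c1nc(Cl)n2Cc1ccccc1`: > 10 uM
- compound 2 `Cc1nc(N)c2nc(O)n(Cc3ccccc3)c2n1`: 1 uM
- compound 3 `COc1ccccc1Cn1c(O)nc2c(N)ncnc21`: 10 uM

In a functional assay (spleen, spleen) for activation, with Mus musculus as the target (a higher number here means that more compound is needed for the effect, a lower number that less compound is needed), compound 1 gives > 10 uM, which is a limit of the assay and not a number, as recorded in the limit of > 10 uM in this assay, at which 1 of the 3 values shown sits. Of the two numbers obtained, compound 2 stands at the lower one: compound 2 gives 1 uM, and compound 3 gives 10 uM, a gap beyond the usual scatter of this kind of measurement. Within the data shown here, no pair of measured compounds differs in a single place, so no measured step is available within the set, and the three structures differ from one another in more than one way.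

Compound 4 `CCCc1nc(N)c2nc(O)n(Cc3ccccc3)c2n1` has not yet been measured in this assay. It differs from compound 2 by ethyl in place of hydrogen on a saturated chain carbon bound to an aromatic carbon. Among the measured compounds shown here, the set holds no measured step of this kind, so the expectation rests on compound 2 alone and on the fact that the change adds chain length without a ring, donor or acceptor. Compound 4 is estimated to give 0.5 uM, with a range from 0.1 uM to 3 uM. The step this estimate implies, a 2.0-fold lower number from compound 2 to compound 4 (0.30 log units; within the scatter), is expected to be small, toward less compound being needed, and may well sit within the scatter.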

Compound 4, minimum effective concentration: 1 uM
Compound 4: middle estimate off by 2.0-fold (0.30 log units), on the low side; measured number inside the range.
By their numbers in this assay, from the lowest: compounds 2 and 4 (each within the scatter of the next); then compound 3.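

In this assay, among these compounds, the replacement of hydrogen by ethyl on a saturated chain carbon bound to an aromatic carbon, which can also be read as methyl to propyl, gives no change at the digits printed from compound 2 to compound 4 (within the scatter) and is the first step that changes a single place. It shows that this position accepts a propyl chain in place of a methyl without a shift that can be told from the scatter, something compound 2 on its own could not show. No measurement in hand gives a reason for this flat step.

From the compounds shown here alone, whether the same position also accepts a longer chain such as hexyl, a chain ending in an amine or in a carboxylic acid, or a phenyl ring in place of the chain stays open, so the limit of what it accepts is not yet defined. Equally open, going by these compounds, is whether the flat step between methyl and propyl would hold if a second place on the shared core were changed as well.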